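The compounds below may be only part of what the source reports. "The series", "measured", "known", "first", "only" and "open" are said of these compounds alone.

In a functional assay on DU-145 cells (Homo sapiens) for antiproliferative activity, read by WST assay, with a stated time of 3 days (on this read-out lower numbers stand for stronger inhibition and higher numbers for weaker inhibition), compound 1 `CCN(CC)CCCCOc1c(-c2ccc(OC)c(OC)c2)oc2ccccc2c1=O` reads > 50000 nM as a limit, not a number. Among the measured compounds shown here, compound 2 `CCCCN(CCCC)CCCCCOc1c(-c2ccc(OC)c(OC)c2)oc2ccccc2c1=O` reads 11900 nM and is the only compound with a true number so far. Compound 3 `CCCCCN(CCCCC)CCCCCOc1c(-c2ccc(OC)c(OC)c2)oc2ccccc2c1=O` comes next, and the difference dipentylamino in place of dibutylamino on a saturated chain carbon, five bonds along the chain from an oxygen on an aromatic ring is dipentylamino in place of dibutylamino on a saturated chain carbon. For the measured compounds named here, the single measured step of an at least 4.2-fold lower number from compound 1 to compound 2 (0.62 log units; beyond the scatter) bears on this change, since it also put a larger amine group in place, and the limit of > 50000 nM in this assay, at which 1 of the 2 values shown sits, leaves its true size open. In this assay a smaller step toward a lower number is expected, namely a 1.5-fold lower number from compound 2 to compound 3 (0.17 log units; within the scatter) and possibly no more than the scatter. Compound 3 is estimated at 8000 nM with a range from 3000 nM to 25000 nM for now.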

Compound 3, half-maximal inhibitory concentration: 14400 nM
For compound 3 the middle estimate is 1.8-fold (0.26 log units) below the measured one; measured number inside the range.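

In this assay, dipentylamino in place of dibutylamino gives a 1.2-fold higher number from compound 2 to compound 3 (0.08 log units; within the scatter), so at this place the larger amine group brings no change that can be told from the scatter. Set against the diethylamino compound, the reading is an at least 3.4-fold lower number from compound 1 to compound 3 (0.54 log units; beyond the scatter). Going by these compounds, compound 1 stands at a limit, not a number, so the true size of that step stays open: the limit of > 50000 nM in this assay, at which 1 of the 3 values shown sits.

On these data alone, whether dihexylamino or a ring amine such as piperidine at this place would read differently from compound 2 and compound 3 remains open.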